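This account rests on a few compounds, and the source may have more. Where it says the series, first, only, none or still open, it means among the compounds named here.

Compound 1 `C=C[C@@](C)(/C=C/c1ccc(O)c(/C=C/c2ccc(F)cc2)c1)CCC=C(C)C`: > 36600 nM, a limit
Compound 2 `C=C[C@@](C)(/C=C/c1ccc(O)c(/C=C/c2ccc(Cl)c(Cl)c2)c1)CCC=C(C)C`: > 7500 nM, a limit
Compound 3 `C=C[C@@](C)(/C=C/c1ccc(O)c(/C=C/C=C/c2ccccc2)c1)CCC=C(C)C`: not yet measured

In a functional assay on SEM cells (Homo sapiens) for cytotoxicity, with a stated time of 72 h (a lower number here means that less compound is needed, a higher number that more compound is needed for the effect), compound 2 has no number, only the limit > 7500 nM. Compound 3 carries 2-phenylethenyl in place of 3,4-dichlorophenyl, on a double-bonded chain carbon bound to a double-bonded chain carbon: 2-phenylethenyl in place of 3,4-dichlorophenyl on a double-bonded chain carbon bound to a double-bonded chain carbon. Among the compounds with values here, the only measured step, a step that the two limits leave unreadable from compound 1 to compound 2, offers no size to carry over, so no clear direction is expected in this assay. The expected step, a step that the limit leaves unreadable from compound 2 to compound 3, is therefore only a rough estimate. For compound 3 the estimated value is 10000 nM, with an expected range of 2500 nM to 40000 nM.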

Compound 3, half-maximal effective concentration: > 15000 nM
Compound 3: only a limit was reported; the forecaster's own chance of this, stated with the estimate: 60%; middle value at least 1.5-fold (0.17 log units) away from the limit.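

In this assay compound 3 gives > 15000 nM, a limit and not a number. Within the data shown here, compound 1 and compound 2 are also reported only as limits, so no step among the three can be read. The compounds shown leave open whether 2-phenylethenyl, 3,4-dichlorophenyl or 4-fluorophenyl makes any difference in this assay.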